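Replacing the bromophenyl arm of a cytotoxic arylidene oxindole

The compounds below may be only part of what the source reports. "The series", "measured", "known", "first", "only" and "open" are said of these compounds alone.

Compound 1 `O=C1/C(=C\c2cccc(Oc3ccccc3)c2)c2ccccc2N1c1c(Cl)cccc1Cl`: > 100 ug/mL; compound 2 `O=C1/C(=C\c2cccc(Br)c2)c2ccccc2N1c1c(Cl)cccc1Cl`: 8 ug/mL; compound 3 `Cc1ccc2nc(Cl)c(/C=C3\C(=O)N(c4c(Cl)cccc4Cl)c4ccccc43)cc2c1`: "not determined" (no result reported).

The three compounds share one core and differ in the arylidene substituent. In a functional assay on B16-F10 cells (Homo sapiens) for cytotoxicity against B16-F10 (Mus musculus), read by MTT assay, with a stated time of 72 h (on this read-out lower numbers stand for an effect already at smaller amounts and higher numbers for an effect only at larger amounts of compound), compound 1 reaches only a limit, > 100 ug/mL, which is a limit of the assay and not a number. Among the compounds with values here, compound 2 gives 8 ug/mL, the only number obtained. For compound 3 no result was reported, "not determined" (no result reported). Among the three, compound 2 is therefore the one compound with a measured value, standing beside one limit and one empty entry. Within the data shown here, the single measured step, an at least 12-fold lower number from compound 1 to compound 2 (1.09 log units; beyond the scatter), is large and lies beyond the scatter, and one of the three entries sits at the limit noted as the limit of > 100 ug/mL in this assay, at which 1 of the 3 values shown sits.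

Compound 4 `O=C1/C(=C\c2ccccc2[N+](=O)[O-])c2ccccc2N1c1c(Cl)cccc1Cl` is not yet measured. Its difference from compound 2 is 2-nitrophenyl in place of 3-bromophenyl on a double-bonded chain carbon bound to a double-bonded ring carbon. Among the measured compounds shown here, the one measured step concerns a change at another group and does not bear on this one; no step to compound 4 has a direct counterpart. The writer therefore expects compound 4 to stay within the region of compound 2, with a modest step, a 2.5-fold higher number from compound 2 to compound 4 (0.40 log units; beyond the scatter), not clearly beyond the scatter. Compound 4 is estimated at 20 ug/mL, with a range from 5 ug/mL to 80 ug/mL.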

Compound 4, concentration for half-maximal effect: > 100 ug/mL
Compound 4 was reported as a limit (the forecaster's own chance of this, stated with the estimate: 20%); middle value at least 5.0-fold (0.69 log units) from the limit.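

At the double-bonded chain carbon bound to a double-bonded ring carbon, putting 2-nitrophenyl in place of 3-bromophenyl gives, in this assay, an at least 12-fold higher number from compound 2 to compound 4 (1.09 log units; beyond the scatter), a large step that shows this arm does not tolerate every substituted phenyl ring. Compound 4 gives > 100 ug/mL, which is a limit of the assay and not a number. Until now only the exchange of phenoxy for bromo had shown how much hangs on this arm, and with a second large step the measured value of compound 2 no longer rests on one comparison, as two different arms now end at the same limit: the limit of > 100 ug/mL in this assay, at which 2 of the 4 values shown sit.

The 2-nitrophenyl arm differs from the 3-bromophenyl arm both in its group and in where that group sits on the ring, so the compounds shown cannot tell which of the two goes with the step. On these data alone, whether an aminophenyl arm or a phenyl ring carrying a carboxylic acid would give a number in this assay stays open, and compound 3, with no result reported, adds nothing on this.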